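A few compounds are considered here, and "the series" means these few. Any claim that something is new, unique, unknown or untested is made for them only; others in the source may bear on it.

Measured compounds:
Compound 1, `Cn1cc(C2=C(c3n[nH]c4ncccc34)C(=O)NC2=O)c2ccccc21`: in a functional assay on KB cells (Homo sapiens) for antiproliferative activity, read by MTT assay, with a stated time of 48 h (on this read-out higher numbers stand for weaker inhibition and lower numbers for stronger inhibition), compound 1 gives 62000 nM.
Compound 2, `Cn1cc(C2=C(c3nn(CCCN4CCCCC4)c4ncccc34)C(=O)N(c3ccccn3)C2=O)c2ccccc21`: in this assay compound 2 reaches only a limit, > 100000 nM.
Compound 3, `Cn1cc(C2=C(c3nn(CCCn4cccc4)c4ncccc34)C(=O)NC2=O)c2ccccc21`: in this assay compound 3 also reaches only a limit, > 100000 nM.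

Compound 2 therefore stands at the limit, where two of the three values sit (the limit of > 100000 nM in this assay, at which 2 of the 3 values shown sit). Within the data shown here, the single measured step, an at least 1.6-fold higher number from compound 1 to compound 3 (0.20 log units; that floor lies within the scatter), concerns a different change and ends at a limit as well. Compound 4, `Cn1cc(C2=C(c3nn(CCCN4CCCCC4)c4ncccc34)C(=O)N(c3ccccc3)C2=O)c2ccccc21`, differs from compound 2 by phenyl in place of pyridin-2-yl on an amide-type nitrogen in a ring. Among the measured compounds shown here, no measured step touches this exchange, so no shift beyond the scatter is expected in this assay. Compound 4 is estimated at 100000 nM, within 30000 nM to 300000 nM. The expected step is a number no higher from compound 2 to compound 4 (the limit leaves the size open).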

Compound 4, half-maximal inhibitory concentration: 5600 nM
Beside the measured number, compound 4's estimate is 18-fold (1.25 log units) above it; measured number outside the range, below it.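

In this assay, the group on the amide-type nitrogen in a ring clearly matters: phenyl in place of pyridin-2-yl, which changes one ring atom from nitrogen to carbon, gives an at least 17-fold lower number from compound 2 to compound 4 (1.25 log units; beyond the scatter). This is the first step shown whose size lies beyond the scatter. Compound 2 stands at a limit, so this size is only a floor: the limit of > 100000 nM in this assay, at which 2 of the 4 values shown sit.

On these data alone, what a methyl or a benzyl group on this nitrogen would give stays open. So does whether phenyl has the same effect alongside the 3-(1H-pyrrol-1-yl)propyl chain of compound 3.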